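Hydroxamate Triazole Series: Aryl Swap at the Triazole Carbon

The source may hold more compounds than are shown below. What is called first, only, known or untested is meant among the compounds shown, and "the series" means these compounds.

Of the compounds shown here, three have been measured in an assay on Sf9 cells for inhibition of protein deacetylase HDAC6 (Homo sapiens), read by fluorescence, with a stated time of 40 min, tested at 100 nM; a lower number here means less inhibition, a higher number more inhibition at the concentration tested (going by the name of the read-out). Compound 1 `O=C(NO)c1ccc(NCc2nc(-c3ccccc3)nn2-c2cccc(Cl)c2)cc1` gives 62.3%. Compound 2 `Cc1ccc(-c2nc(CNc3ccc(C(=O)NO)cc3)n(-c3ccccc3)n2)cc1` gives 62.2%, the second highest of the three numbers; its nearest neighbour is compound 1, whose number is higher by an amount within the scatter, so the two cannot be ordered. The furthest is compound 3 `O=C(O)c1ccc(NCc2nc(-c3ccccc3)nn2-c2ccccc2)cc1`, which in this assay gives -0.4%, a gap to compound 2 that lies beyond the scatter. Within the data shown here, no pair of measured compounds differs in only one place, so no single step can be read off the data.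

Compound 4 `O=C(NO)c1ccc(NCc2nc(-c3ccccn3)nn2-c2ccccc2)cc1` has not yet been measured. It differs from compound 2 in one place: pyridin-2-yl in place of 4-methylphenyl on an aromatic carbon. Among the measured compounds shown here, the two measured hydroxamates, compound 1 and compound 2, sit close together while carrying different aryl groups on the core, so on the evidence available the number in this assay is level across the two aryl groups at this position, though only two examples support that. The step from compound 2 to compound 4 is therefore expected to be small, possibly a slight decrease, but not clearly beyond the scatter; the expected step is a number 7.2 percentage points lower from compound 2 to compound 4 (within the scatter). Compound 4 is estimated to give 55% in this assay, with a likely range from 35% to 72%.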

Compound 4, a percentage reported as inhibition, at one concentration (the size of the read-out at that concentration, not a potency): 58.6%
For compound 4 the middle estimate is 3.6 percentage points below the measured one; the range from low to high includes it.
By their numbers in this assay, from the lowest: compound 3; then compounds 4, 2 and 1 (each within the scatter of the next).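

In this assay, among these compounds, the step of a number 3.6 percentage points lower from compound 2 to compound 4 (within the scatter) is the first single-place comparison available, and it lies within the scatter, so the two compounds cannot be told apart. At this aromatic carbon, between two ring nitrogen atoms, a ring of carbon only with 7 heavy atoms can thus be exchanged for a ring with 1 hetero atom, 1 hydrogen-bond acceptor and 6 heavy atoms without a step beyond the scatter, although this rests on a single pair. No available data offer an explanation for this result.

All the aryl groups shown at this position are six-membered aromatic rings, so it remains open whether the number in this assay would stay level with a non-aromatic group such as piperidin-1-yl, an aminomethyl group or a longer alkyl chain on the same carbon. Also open, from the compounds shown here alone, is whether pyridin-3-yl or pyridin-4-yl would behave like pyridin-2-yl, and whether compounds that cannot be separated at this single concentration would also match across a range of concentrations.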